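Swapping the benzylic aryl group: what compound 4 may tolerate

The source may hold more compounds than are shown below. What is called first, only, known or untested is meant among the compounds shown, and "the series" means these compounds.

Compound 1, `Cc1c(Cc2ccccc2)c(=O)oc2cc(OCC(O)CNC3CCOCC3)ccc12`: 38200 nM
Compound 2, `Cc1c(Cc2ccc(F)cc2)c(=O)oc2cc(OCC(O)CN3CCC(C(N)=O)CC3)ccc12`: 89300 nM
Compound 3, `Cc1c(Cc2ccc(F)cc2F)c(=O)oc2cc(OCC(O)CN3CCC(C(N)=O)CC3)ccc12`: > 100000 nM

Of the compounds shown here, three sharing one core have been tested in an ADME assay on A549 cells (Homo sapiens) for cytotoxicity, read by CellTiter-Glo; a lower number here means that less compound is tolerated, a higher number that more compound is tolerated. Compound 1 gives 38200 nM in this assay, and compound 2 gives 89300 nM; these two differ in more than one place, so only their two values can be set side by side. For compound 3 the assay reports only a limit, > 100000 nM, and no number. Among the compounds with values here, the one single-point step in the set, an at least 1.1-fold higher number from compound 2 to compound 3 (0.04 log units; that floor lies within the scatter), stays within the usual scatter, so the two fluorine patterns cannot be told apart on this read-out; the relevant observation is the limit of > 100000 nM in this assay, at which 1 of the 3 values shown sits.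

Compound 4, `COC(=O)c1ccc(Cc2c(C)c3ccc(OCC(O)CN4CCC(C(N)=O)CC4)cc3oc2=O)cc1`, is not yet measured. It differs from compound 3 by 4-(methoxycarbonyl)phenyl in place of 2,4-difluorophenyl on a saturated chain carbon bound to an aromatic carbon. Within the data shown here, no measured step changes this part of the molecule in the same way, so the only guidance is that compound 3 already sits at the limit and that the one change tested at the benzylic aryl group moved this assay by nothing beyond scatter. Compound 4 is therefore expected to show no shift beyond the scatter, a number no higher from compound 3 to compound 4 (the limit leaves the size open), and its cytotoxicity in this assay is estimated at 100000 nM, with a range from 45000 nM to 220000 nM; a second limit rather than a number is a real possibility.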

Compound 4, half-maximal cytotoxic concentration: > 100000 nM
Compound 4 was reported as a limit; the forecaster's own chance of this, stated with the estimate: 60%; the middle value lies on the limit itself.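

In this assay compound 4 is reported only as a limit, > 100000 nM. Methoxycarbonyl in place of fluoro on an aromatic carbon gives the one new step that can be read, an at least 1.1-fold higher number from compound 2 to compound 4 (0.04 log units; that floor lies within the scatter), so this change, like the added fluoro before it, has no shift that can be told from the scatter, and only a floor of its size is known. The step between the two limit compounds cannot be read, but this place now holds a 4-(methoxycarbonyl)phenyl group, with 2 hydrogen-bond acceptors where 2,4-difluorophenyl has none, and the result is a second compound at the same limit: the limit of > 100000 nM in this assay, at which 2 of the 4 values shown sit.

From the compounds shown here alone, how far compound 3 and compound 4 lie beyond that limit stays open, and with it whether 2,4-difluorophenyl and 4-(methoxycarbonyl)phenyl differ at all in this assay. Also open, going by these compounds, is whether a carboxylic acid or an amine on the aromatic ring of the benzyl group, or a longer chain in place of that benzyl group, would give a number rather than a limit.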